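The source may report more compounds than this note shows. Statements on the series, on what has been measured and on what is new or still open speak of the compounds shown alone.

The series shares one core, seen in compound 1 `CCOc1nc(N)nc2c1ncn2/C=C1/CC1(CO)CO`, compound 2 `COCCOc1nc(N)nc2c1ncn2/C=C1/CC1(CO)CO` and compound 3 `CC(C)Nc1nc(N)nc2c1ncn2/C=C1/CC1(CO)CO`, and differs only in the group on the aromatic carbon. In an ADME assay on BCBL1 cells (Homo sapiens) for cytotoxicity, with a stated time of 7 days (a lower number here means that less compound is tolerated, a higher number that more compound is tolerated), compound 1 gives only a limit, > 20000 nM. In this assay compound 2 likewise gives only a limit, > 20000 nM. Compound 3 stands at a limit as well, > 20000 nM in this assay. The three steps, a step that the two limits leave unreadable from compound 1 to compound 2, a step that the two limits leave unreadable from compound 1 to compound 3 and a step that the two limits leave unreadable from compound 2 to compound 3, are therefore unreadable in size, and all three values sit at the limit of > 20000 nM in this assay, at which 3 of the 3 values shown sit.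

Compound 4 `CCCCCCSc1nc(N)nc2c1ncn2/C=C1/CC1(CO)CO` carries hexylsulfanyl in place of isopropylamino on an aromatic carbon. Going by the values given here, none of the measured steps gives a readable size, so the change from isopropylamino to hexylsulfanyl has no measured precedent in this set; the steps to the other two compounds only show that the limit was reached each time. Compound 4 is expected to give 20000 nM in this assay, within 5000 nM to 60000 nM. The step of a number no higher from compound 3 to compound 4 (the limit leaves the size open) is thus estimated as no clear movement beyond the scatter, with a fair chance that only a limit is again reported.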

Compound 4, half-maximal cytotoxic concentration: > 20000 nM
Compound 4 was reported as a limit (the forecaster's own chance of this, stated with the estimate: 60%); the middle value sits exactly at the limit.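

In this assay the steps from compounds 1, 2 and 3 to compound 4 cannot be read, with every value a limit: the limit of > 20000 nM in this assay, at which 4 of the 4 values shown sit. The compounds shown leave open whether the group on the aromatic carbon shifts the half-maximal cytotoxic concentration at all.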